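Swapping the isobutylamino group of compound 2 for hydrogen

A few compounds are considered here, and "the series" means these few. Any claim that something is new, unique, unknown or untested is made for them only; others in the source may bear on it.

Of the compounds shown here, two built on the same core have been measured in an ADME assay on L6 cells (Rattus norvegicus) for cytotoxicity, read by resazurin assay, with a stated time of 72 h; on this read-out lower numbers stand for stronger inhibition and higher numbers for weaker inhibition. In this test, compound 1 (`NC(c1ccc(Cl)cc1)(c1cccnc1)c1ccccc1Cl`) gives 76000 nM and compound 2 (`CC(C)CNC(c1ccc(Cl)cc1)(c1cccnc1)c1ccccc1Cl`) gives 59200 nM, so compound 2 stands level with compound 1, within the scatter of repeated measurements.

The next compound, compound 3 (`Clc1ccc(C(c2cccnc2)c2ccccc2Cl)cc1`), is reached from compound 2 by one structural change: hydrogen in place of isobutylamino on a saturated chain carbon bound to three aromatic carbons. Put simply, hydrogen takes the place of isobutylamino on a saturated chain carbon bound to three aromatic carbons.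

Among the measured compounds shown here, only one measured step bears on this change. Adding the isobutyl to the amine nitrogen of compound 1 gave a 1.3-fold lower number from compound 1 to compound 2 (0.11 log units; within the scatter). For the measured compounds named here, that step covers only part of the group now leaving, and no measured pair shows what removing the amine nitrogen itself does. A shift beyond the scatter is therefore not expected, but the range has to stay wide.

The expected change is a 1.0-fold higher number from compound 2 to compound 3 (0.01 log units; within the scatter). For compound 3, the estimated value in this assay is 60000 nM, within an expected range of 25000 nM to 130000 nM.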

Compound 3, half-maximal inhibitory concentration: 62300 nM
Beside the measured number, compound 3's estimate is 1.0-fold (0.02 log units) below it; the range from low to high includes it.
By their numbers in this assay, from the lowest: compounds 2, 3 and 1 (each within the scatter of the next).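

In this assay taking away the whole isobutylamino group, nitrogen included, gives a 1.1-fold higher number from compound 2 to compound 3 (0.02 log units; within the scatter) and so shows what the earlier pair could not: the amine nitrogen itself can leave this saturated chain carbon bound to three aromatic carbons without the number moving beyond the scatter. The comparison with the unsubstituted amine agrees, with a 1.2-fold lower number from compound 1 to compound 3 (0.09 log units; within the scatter) on the same carbon, so hydrogen, amino and isobutylamino all stand level at this position, and the hydrogen-bond donor and acceptor that leave with the isobutylamino group make no difference that this test can detect. No other measurement is at hand to explain why these three compounds stand level.

What these compounds leave open is whether this position stays as undemanding for other kinds of group, such as a hydroxyl, a carboxylic acid or a longer chain on the same carbon. They also leave open whether a change elsewhere on the shared core, such as replacing one of the chlorines with hydrogen, would move the number beyond the scatter.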